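Moving the chlorine of a urea in two related cores

The source may report more compounds than this note shows. Statements on the series, on what has been measured and on what is new or still open speak of the compounds shown alone.

Of the compounds shown here, three have so far been measured in a functional assay on MKN-45 cells (Homo sapiens) for cytotoxicity, read by MTT assay, with a stated time of 72 h; on this read-out higher numbers stand for weaker inhibition and lower numbers for stronger inhibition. Compound 1 `CN(C)CCNc1nc(-c2ccc(NC(=O)Nc3ccc(Cl)cc3)cc2)nc2ccsc12` gives 250 nM in this assay. Compound 2 `CN(C)CCNc1nc(-c2ccc(NC(=O)Nc3ccccc3Cl)cc2)nc2ccsc12` differs from compound 1 only in one spot: 2-chlorophenyl in place of 4-chlorophenyl on an amide-type nitrogen. In this assay compound 2 gives 850 nM, and the step is a 3.4-fold higher number from compound 1 to compound 2 (0.53 log units; beyond the scatter). Compound 3 `CCN(CC)CCCNc1nc(-c2ccc(NC(=O)Nc3ccc(Cl)cc3)cc2)nc2c(Cl)c(Cl)sc12` is built on a different core; how its core differs from that of compound 1 is not broken down here. In this assay compound 3 gives 720 nM, a number within the scatter of compound 2 and higher than that of compound 1.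

Compound 4 `CCN(CC)CCCNc1nc(-c2ccc(NC(=O)Nc3ccccc3Cl)cc2)nc2c(Cl)c(Cl)sc12` has not yet been measured. It relates to compound 3 exactly as compound 2 relates to compound 1: 2-chlorophenyl in place of 4-chlorophenyl on an amide-type nitrogen. The surroundings of the change are the same in both pairs, so this is the same change carried over to a second core. Because the earlier instance gave a 3.4-fold higher number from compound 1 to compound 2 (0.53 log units; beyond the scatter), a similar weakening is expected here, though a single precedent leaves real uncertainty. Compound 4 is therefore expected to show a 3.2-fold higher number from compound 3 to compound 4 (0.50 log units; beyond the scatter) in this assay. The estimated value for compound 4 is 2300 nM, expected to fall between 900 nM and 6000 nM.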

Compound 4, half-maximal inhibitory concentration: 1450 nM
Beside the measured number, compound 4's estimate is 1.6-fold (0.20 log units) above it; low and high end bracket the measured number.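

In this assay, putting 2-chlorophenyl in place of 4-chlorophenyl on the core of compound 3 gives a 2.0-fold higher number from compound 3 to compound 4 (0.30 log units; within the scatter), so on this core the change cannot be told apart from the ordinary spread of repeated measurements. Set beside the first pair, the result fits a change that carries over between the two cores with a similar size and the same direction, since the gap between the two steps is no larger than the scatter allows: the same change on two cores in this assay, a 3.4-fold higher number (0.53 log units; beyond the scatter) from compound 1 to compound 2 and a 2.0-fold higher number (0.30 log units; within the scatter) from compound 3 to compound 4, 1.7-fold (0.23 log units) apart, within the scatter of two such steps. For the compounds shown here, it does not show that the change weakens activity on every core, as only the step on the core of compound 1 lies beyond the scatter, and two pairs are too few to establish a rule for the series.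

Still open, on these data alone, is whether the same pattern would hold with a group other than chlorine on the phenyl ring, such as fluorine, methoxy or trifluoromethyl. Also open, as far as these compounds go, is whether a urea replaced by a plain amide would respond to this change in the same way.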